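From nitro to cyclopropylmethoxy on the cyano-bearing ring

This account rests on a few compounds, and the source may have more. Where it says the series, first, only, none or still open, it means among the compounds named here.

Three compounds have numbers in a functional assay with metabotropic glutamate receptor 5 (Rattus norvegicus) as the target; on this read-out higher numbers stand for weaker inhibition and lower numbers for stronger inhibition:
Compound 1 `N#Cc1cccc(-n2nnc(-c3ccccn3)n2)c1` gives 73 nM.
Compound 2 `N#Cc1cc(C#N)cc(-n2nnc(-c3ccccn3)n2)c1` gives 34 nM.
Compound 3 `N#Cc1cc(-n2nnc(-c3ccccn3)n2)cc([N+](=O)[O-])c1` gives 42 nM.

Compound 3 stands second highest of the three, with the step of a 1.2-fold higher number from compound 2 to compound 3 (0.09 log units; within the scatter) and the step of a 1.7-fold lower number from compound 1 to compound 3 (0.24 log units; within the scatter) both within the scatter. Compound 4 `N#Cc1cc(OCC2CC2)cc(-n2nnc(-c3ccccn3)n2)c1` differs from compound 3 by cyclopropylmethoxy in place of nitro on an aromatic carbon. For the measured compounds named here, no measured step exchanges nitro for anything other than hydrogen. The steps that touch this carbon are a 2.1-fold lower number from compound 1 to compound 2 (0.33 log units; beyond the scatter) and a 1.7-fold lower number from compound 1 to compound 3 (0.24 log units; within the scatter); both were small, so only a modest step, or none beyond the scatter, is expected for compound 4, in either direction. Compound 4 is estimated at 60 nM (range 20 nM to 180 nM), an expected step of a 1.4-fold higher number from compound 3 to compound 4 (0.15 log units; within the scatter).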

Compound 4, half-maximal inhibitory concentration: 975 nM
For compound 4 the middle estimate is 16-fold (1.21 log units) below the measured one; the whole stated range lies below it.
By their numbers in this assay, from the lowest: compounds 2, 3 and 1 (each within the scatter of the next, the first and the last beyond it); then compound 4.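

Cyclopropylmethoxy on this aromatic carbon brings the first large steps in this assay: a 23-fold higher number from compound 3 to compound 4 (1.37 log units; beyond the scatter), a 29-fold higher number from compound 2 to compound 4 (1.46 log units; beyond the scatter) and a 13-fold higher number from compound 1 to compound 4 (1.13 log units; beyond the scatter). The steps among hydrogen, nitro and cyano at this carbon were small, so they did not show that a group here could weaken inhibition this much, with compound 4 now well behind all three. No measurement at hand accounts for this loss. From the compounds shown here alone, it remains open whether the cyclopropyl ring or the ether oxygen carries the step, and how a methoxy group or an amine on this carbon would read.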